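The compounds below may be only part of what the source reports. "The series", "measured", "known", "first", "only" and "open" are said of these compounds alone.

Three compounds share one core and differ only in the group on a saturated chain carbon bound to an amide-type nitrogen and an aromatic carbon. Compound 1 `CCC[C@@H](NC(=O)c1nccs1)c1cnc(Nc2ccc(C)nc2)c(Cl)c1` carries a propyl there, compound 2 `Cc1ccc(Nc2ncc([C@H](NC(=O)c3nccs3)C(C)C)cc2Cl)cn1` an isopropyl, and compound 3 `Cc1ccc(Nc2ncc([C@H](NC(=O)c3nccs3)C3CC3)cc2Cl)cn1` a cyclopropyl. In a functional assay on HEK293 cells for negative allosteric modulation of metabotropic glutamate receptor 5 (Homo sapiens), read by HTRF and inositol phosphate accumulation (on this read-out lower numbers stand for stronger inhibition and higher numbers for weaker inhibition), compound 1 gives 8.2 nM, compound 2 gives 7.5 nM, and compound 3 gives 9.7 nM. Compound 3 thus has the highest of these three numbers, yet every gap among them is small: a 1.1-fold lower number from compound 1 to compound 2 (0.04 log units; within the scatter), a 1.2-fold higher number from compound 1 to compound 3 (0.07 log units; within the scatter) and a 1.3-fold higher number from compound 2 to compound 3 (0.11 log units; within the scatter), none of them beyond the scatter.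

Compound 4 `Cc1ccc(Nc2ncc([C@H](NC(=O)c3nccs3)C3CCCC3)cc2Cl)cn1` continues the series with cyclopentyl in place of cyclopropyl on a saturated chain carbon bound to an amide-type nitrogen and an aromatic carbon. All three measured steps bear on this change, since each swapped the group at the same place, and each stayed within the scatter. Among the compounds with values here, no measured step tests a ring of this size, so the expectation rests on the observation that the three groups tried so far gave numbers that cannot be told apart. The step from compound 3 to compound 4 is therefore expected to be small, a 1.1-fold higher number from compound 3 to compound 4 (0.05 log units; within the scatter), with no direction favoured beyond the scatter. Compound 4 is estimated to give 11 nM in this assay, within a range from 4.5 nM to 28 nM.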

Compound 4, half-maximal inhibitory concentration: 16.6 nM
Beside the measured number, compound 4's estimate is 1.5-fold (0.18 log units) below it, within the range that was stated.
By their numbers in this assay, from the lowest: compounds 2, 1, 3 and 4 (each within the scatter of the next, the first and the last beyond it).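

In this assay, within the data shown here, cyclopentyl is the first group at this place on the saturated chain carbon to open a gap beyond the scatter, though a modest one, with a 2.2-fold higher number from compound 2 to compound 4 (0.35 log units; beyond the scatter) and a 2.0-fold higher number from compound 1 to compound 4 (0.31 log units; beyond the scatter) as the two steps that show it. The third step stays within the scatter (a 1.7-fold higher number from compound 3 to compound 4 (0.23 log units; within the scatter)), so compound 4 cannot be told apart from compound 3, and the place shows only a limited sensitivity to the group it carries, visible against the propyl of compound 1 and the isopropyl of compound 2 but not against the cyclopropyl of compound 3. Nothing measured here explains why cyclopentyl separates from those two groups.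

As far as these compounds go, a single ring of this size cannot establish a trend, so it stays open whether cyclobutyl or cyclohexyl would fall in line with compound 4 or with the first three compounds. Also open, from the compounds shown here alone, is how this place would respond to a group of a different kind, such as a tetrahydropyranyl ring, a methoxymethyl chain or an amine.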